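The source may hold more compounds than are shown below. What is called first, only, known or untested is meant among the compounds shown, and "the series" means these compounds.

Three compounds share one core, a six-membered aromatic ring with one nitrogen bearing three aromatic groups. Compound 1 `Oc1cccc(-c2cc(-c3ccc(F)cc3)cc(-c3ccccc3O)n2)c1` reaches in a functional assay on HeLa cells (Homo sapiens) for inhibition (a higher number here means a weaker inhibitor, a lower number a stronger inhibitor), only a limit of the assay, > 50000 nM. Compound 2 `Oc1ccc(-c2cc(-c3cccc(F)c3)cc(-c3cccc(O)c3)n2)cc1` gives 14200 nM in this assay. Compound 3 `Oc1cccc(-c2cc(-c3ccccc3C(F)(F)F)cc(-c3ccccc3O)n2)c1` gives 16800 nM in this assay; the gap to compound 2 is within the usual scatter, so the two cannot be told apart. For the measured compounds named here, the single step measured between compounds differing in one place is an at least 2.9-fold lower number from compound 1 to compound 3 (0.47 log units; beyond the scatter), and its size rests on (the limit of > 50000 nM in this assay, at which 1 of the 3 values shown sits).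

Compound 4 `Oc1ccc(-c2cc(-c3ccccc3C(F)(F)F)cc(-c3cccc(O)c3)n2)cc1` differs from compound 3 in one place: 4-hydroxyphenyl in place of 2-hydroxyphenyl on an aromatic carbon. Going by the values given here, no measured pair isolates this change. Compound 2 does carry a 4-hydroxyphenyl group, but it differs from compound 1 in a second place too, so their values cannot be read as a step for the hydroxyl position alone. Among the compounds with values here, the one measured step concerns a different group, so it gives no direction here, and no shift beyond the scatter is expected. Compound 4 is therefore expected to give about 12000 nM in this assay, likely between 4000 nM and 40000 nM. The expected step is a 1.4-fold lower number from compound 3 to compound 4 (0.15 log units; within the scatter).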

Compound 4, half-maximal inhibitory concentration: 17400 nM
Beside the measured number, compound 4's estimate is 1.5-fold (0.16 log units) below it; low and high end bracket the measured number.
By their numbers in this assay, from the lowest: compounds 2, 3 and 4 (each within the scatter of the next). At a limit, above all of these: compound 1.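

In this assay, for the compounds shown here, 4-hydroxyphenyl in place of 2-hydroxyphenyl on the aromatic carbon next to the ring nitrogen gives a 1.0-fold higher number from compound 3 to compound 4 (0.02 log units; within the scatter) and is the first direct reading of this change, so with a 2-(trifluoromethyl)phenyl group present, the two hydroxyphenyl groups cannot be told apart. Compound 4 also gives a direct reading at the other varied group, where 2-(trifluoromethyl)phenyl in place of 3-fluorophenyl gives a 1.2-fold higher number from compound 2 to compound 4 (0.09 log units; within the scatter) and these two groups likewise cannot be told apart. Nothing measured here accounts for either result.

The compounds shown leave open whether the hydroxyl swap would also make no difference alongside a 4-fluorophenyl or 3-fluorophenyl group, since each hydroxyl arrangement is paired with only some of these groups. They also leave open whether an amine or a carboxylic acid in place of the hydroxyl on this ring would shift the number beyond the scatter, because every compound shown carries a hydroxyl at this place.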